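The source may hold more compounds than are shown below. What is called first, only, known or untested is meant among the compounds shown, and "the series" means these compounds.

Compound 3 `Cn1nnc(-c2c(F)cc(Cl)cc2-c2cnc(CNC(=O)N(O)C3CCCC3)c(F)c2)n1` gives 0.8 nM in a functional assay on IMR-90 cells for antagonist activity at B1 bradykinin receptor (Homo sapiens), read by calcium flux (a higher number here means a weaker inhibitor, a lower number a stronger inhibitor), the lowest number among the three measured; its step from compound 2 `CC(C)N(O)C(=O)NCc1ncc(-c2cc(Cl)cc(F)c2-c2nnn(C)n2)cc1F`, which gives 1 nM, is a 1.3-fold lower number from compound 2 to compound 3 (0.10 log units; within the scatter), while compound 1 `CN(O)C(=O)NCc1ncc(-c2cc(Cl)cc(F)c2-c2nnn(C)n2)cc1F` gives 17 nM, a difference of a 21-fold lower number from compound 1 to compound 3 (1.33 log units; beyond the scatter). Compound 4 `Cn1nnc(-c2c(F)cc(Cl)cc2-c2cnc(CNC(=O)N(O)C3CCCCC3)c(F)c2)n1` differs from compound 3 by cyclohexyl in place of cyclopentyl on an amide-type nitrogen. The steps of a 17-fold lower number from compound 1 to compound 2 (1.23 log units; beyond the scatter) and a 21-fold lower number from compound 1 to compound 3 (1.33 log units; beyond the scatter) show that enlarging the methyl on this nitrogen brought large gains, yet a 1.3-fold lower number from compound 2 to compound 3 (0.10 log units; within the scatter) shows that further growth from isopropyl to cyclopentyl changed nothing beyond the scatter. Adding one more ring carbon is therefore expected to leave this assay essentially unchanged, a step of no change at the digits printed from compound 3 to compound 4 (within the scatter). Compound 4 is accordingly estimated at 0.8 nM, within a range of 0.4 nM to 2 nM.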

Compound 4, half-maximal inhibitory concentration: 3.9 nM
For compound 4 the middle estimate is 4.9-fold (0.69 log units) below the measured one, and the stated range ends below it.
By their numbers in this assay, from the lowest: compounds 3 and 2 (each within the scatter of the next); then compound 4; then compound 1.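

On this amide-type nitrogen, the gain from enlarging the group has a limit: in this assay, cyclohexyl gives a 4.9-fold higher number from compound 3 to compound 4 (0.69 log units; beyond the scatter) and a 3.9-fold higher number from compound 2 to compound 4 (0.59 log units; beyond the scatter), so one more ring carbon raises the number, although the earlier change from isopropyl to cyclopentyl stayed within the scatter. Cyclohexyl still retains part of the gain over methyl, with a 4.4-fold lower number from compound 1 to compound 4 (0.64 log units; beyond the scatter). No evidence available here accounts for this turn. The compounds shown leave open how a longer chain such as n-butyl or an oxygen-containing ring such as tetrahydropyranyl would behave on this nitrogen. Every compound shown also keeps the hydroxy group there, so replacing it with hydrogen or methoxy remains an open question.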